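Methoxy added to the phenyl of compound 3

The compounds below may be only part of what the source reports. "The series", "measured", "known", "first", "only" and "open" are said of these compounds alone.

Compound 3 `Cn1cc(C2CC(c3ccccc3)=NN2C(=O)c2cccnc2)c2cc(Br)ccc21` gives 1520 nM in a functional assay on MCF7 cells (Homo sapiens) for inhibition, read by MTT assay, with a stated time of 48 h (on this read-out lower numbers stand for stronger inhibition of growth and higher numbers for weaker inhibition of growth), and shares the upper end of the series with compound 1 `Cn1cc(C2CC(c3ccccc3)=NN2C(=O)c2ccncc2)c2ccccc21` at 1110 nM within the scatter. Compound 2 `COc1cc(C2=NN(C(=O)c3ccc(C)nc3)C(c3cn(C)c4ccccc34)C2)cc(OC)c1OC` at 180 nM lies beyond the scatter on the lower side and alone among the three carries methoxy groups. Compound 4 `COc1ccc(C2=NN(C(=O)c3cccnc3)C(c3cn(C)c4ccc(Br)cc34)C2)cc1` changes compound 3 by methoxy in place of hydrogen on an aromatic carbon as methoxy in place of hydrogen on an aromatic carbon, para to a large group. Within the data shown here, no measured pair isolates this change. Compound 2 at 180 nM differs from compound 3 in several places and gives only weak support for a fall in this assay here. The estimate expects a 2.3-fold lower number from compound 3 to compound 4 (0.37 log units; beyond the scatter) toward a lower number. For compound 4 the estimated value is 650 nM with an expected range from 220 nM to 1800 nM in this series.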

Compound 4, concentration for 50% growth inhibition: 1560 nM
The estimate for compound 4 lay 2.4-fold (0.38 log units) below the measured number; the measured number falls inside the stated range.
By their numbers in this assay, from the lowest: compound 2; then compounds 1, 3 and 4 (each within the scatter of the next).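

In this assay, among these compounds, methoxy in place of hydrogen on the phenyl, para to a large group, gives a 1.0-fold higher number from compound 3 to compound 4 (0.01 log units; within the scatter), the first direct reading of this change. On the core of compound 3, this position accepts methoxy with no change beyond the scatter, a finding that rests on this single pair. No measurement shown accounts for this flat step.

Going by these compounds, whether an amine, a carboxylic acid or a longer chain such as butoxy at this position would read the same stays open. Also open, on these data alone, is whether methoxy gives the same step on a core without the bromine.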